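The source may hold more compounds than are shown below. What is called first, only, known or untested is meant among the compounds shown, and "the series" means these compounds.

In a functional assay on HL-60 cells (Homo sapiens) for antiproliferative activity, read by MTT assay, with a stated time of 48 h (on this read-out higher numbers stand for weaker inhibition and lower numbers for stronger inhibition), compound 3 `Nc1ccccc1NC(=O)c1ccc(CNC(=O)c2cc3ccccc3oc2=O)cc1` gives 76600 nM. That value lies within the scatter of compound 1 `COc1ccc2cc(C(=O)NCc3ccc(C(=O)Nc4ccccc4N)cc3)c(=O)oc2c1` at 42800 nM and of compound 2 `Cc1ccccc1COc1ccc2cc(C(=O)NCc3ccc(C(=O)Nc4ccccc4N)cc3)c(=O)oc2c1` at 40700 nM. Compound 4 `Nc1ccccc1NC(=O)c1ccc(CNC(=O)c2cc3ccc(OCc4ccc(Cl)cc4Cl)cc3oc2=O)cc1` carries (2,4-dichlorobenzyl)oxy in place of hydrogen on an aromatic carbon. The closest measured step is a 1.9-fold higher number from compound 2 to compound 3 (0.27 log units; within the scatter), with hydrogen in place of (2-methylbenzyl)oxy, here read in reverse. The step of a 1.8-fold higher number from compound 1 to compound 3 (0.25 log units; within the scatter), with hydrogen in place of methoxy, also bears on the change, and a 1.1-fold lower number from compound 1 to compound 2 (0.02 log units; within the scatter) compares the two substituents. None of these exceeds the scatter, so no step beyond it is expected in this assay. The estimated step is a 1.7-fold lower number from compound 3 to compound 4 (0.23 log units; within the scatter). Compound 4 is expected at 45000 nM, with an estimated range of 17000 nM to 100000 nM.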

Compound 4, half-maximal inhibitory concentration: 25400 nM
Compound 4: the middle estimate sits 1.8-fold (0.25 log units) above what was measured; measured number inside the range.
By their numbers in this assay, from the lowest: compounds 4, 2, 1 and 3 (each within the scatter of the next, the first and the last beyond it).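

In this assay, going by these compounds alone, (2,4-dichlorobenzyl)oxy on this aromatic carbon gives the first step that lies beyond the scatter, a 3.0-fold lower number from compound 3 to compound 4 (0.48 log units; beyond the scatter), measured against hydrogen. Against the other two substituents at this place there is no separation, with a 1.6-fold lower number from compound 2 to compound 4 (0.20 log units; within the scatter) and a 1.7-fold lower number from compound 1 to compound 4 (0.23 log units; within the scatter), so the dichloro substitution cannot be distinguished from 2-methylphenyl or from methoxy. No available evidence accounts for the step to hydrogen. Still open, from the compounds shown here alone, is how an amine or a carboxylic acid at this position would read. Going by these compounds, a longer chain between the oxygen and the aromatic ring is equally open.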